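The source may hold more compounds than are shown below. What is called first, only, known or untested is meant among the compounds shown, and "the series" means these compounds.

Compound 1, `COc1c(/C=C2/C(=O)Nc3ccccc32)c2ccccc2n1-c1ccccc1`: 4070 nM in a functional assay on cells (Cancer cell lines, Homo sapiens) for cytotoxicity, with a stated time of 48 h; a lower number here means a stronger inhibitor of growth, a higher number a weaker inhibitor of growth.
Compound 2, `O=C1Nc2ccccc2/C1=C\c1c(Cl)n(CCCc2ccccc2)c2ccccc12`: 67600 nM in this assay.
Compound 3, `COc1c(/C=C2/C(=O)Nc3ccc(Cl)cc32)c2ccccc2n1-c1ccccc1`: 21900 nM in this assay.

Compound 3 differs from compound 1 in one place only: chloro in place of hydrogen on an aromatic carbon. That single change produced a 5.4-fold higher number from compound 1 to compound 3 (0.73 log units; beyond the scatter), so compound 3 is the weaker growth inhibitor of the two. Compound 4, `O=C1Nc2ccc(Cl)cc2/C1=C\c1c(Cl)n(CCCc2ccccc2)c2ccccc12`, has not yet been measured; it differs from compound 2 by the same change, (chloro in place of hydrogen on an aromatic carbon). How the core of compound 2 differs from that of compound 1 is not broken down here, but compound 2 already gives the highest number of the three. Because the earlier step of a 5.4-fold higher number from compound 1 to compound 3 (0.73 log units; beyond the scatter) went upward, the step from compound 2 to compound 4 is expected to go the same way, estimated as a 3.7-fold higher number from compound 2 to compound 4 (0.57 log units; beyond the scatter). Compound 4 is therefore expected to give about 250000 nM in this assay, most likely between 80000 nM and 800000 nM, with a real chance that only a limit is reported.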

Compound 4, concentration for total growth inhibition: 9770 nM
Estimate against measurement, compound 4: 26-fold (1.41 log units) above; measured number outside the range, below it.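

In this assay, chloro in place of hydrogen on an aromatic carbon gave a 6.9-fold lower number from compound 2 to compound 4 (0.84 log units; beyond the scatter) and so a stronger growth inhibitor. On the other core the same change went the opposite way, so neither its direction nor its size carried over: the same change on two cores in this assay, a 5.4-fold higher number (0.73 log units; beyond the scatter) from compound 1 to compound 3 and a 6.9-fold lower number (0.84 log units; beyond the scatter) from compound 2 to compound 4, 37-fold (1.57 log units) apart, beyond the scatter of two such steps

The two cores differ in more than one place, and these two pairs do not show which of those differences turns the step around or what the change would do on a further core. Also open, as far as these compounds go, is how other groups would behave in the place of the chloro on each core, such as a fluoro or an amine. Among these compounds, a compound with only one of the core differences would help separate these effects.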